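Swapping the Amide Aryl Group on a Shared Core

This account rests on a few compounds, and the source may have more. Where it says the series, first, only, none or still open, it means among the compounds named here.

Compound 1, `Cc1ccc(F)cc1NC(=O)CN1CCN(c2nnc(Cc3ccccc3)c3ccccc23)CC1`, gives 19200 nM in a functional assay on MDA-MB-231 cells (Homo sapiens) for cytotoxicity, read by MTT assay, with a stated time of 72 h; on this read-out higher numbers stand for weaker inhibition and lower numbers for stronger inhibition.
Compound 2, `O=C(CN1CCN(c2nnc(Cc3ccccc3)c3ccccc23)CC1)Nc1ccc(F)c(F)c1`, gives 2750 nM in this assay.
Compound 3, `O=C(CN1CCN(c2nnc(Cc3ccccc3)c3ccccc23)CC1)Nc1cccc(Br)c1`, gives 3880 nM in this assay.

All three share one core and differ only in the aryl group on the amide-type nitrogen. Compound 3 stands second highest of the three numbers: its nearest neighbour is compound 2, with a 1.4-fold higher number from compound 2 to compound 3 (0.15 log units; within the scatter), while its furthest is compound 1, with a 4.9-fold lower number from compound 1 to compound 3 (0.69 log units; beyond the scatter). The remaining measured step, a 7.0-fold lower number from compound 1 to compound 2 (0.84 log units; beyond the scatter), shows the same picture: leaving the 5-fluoro-2-methylphenyl group gave a modest gain, whereas the exchange between two halogenated phenyl groups stayed within the scatter.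

Compound 4, `O=C(CN1CCN(c2nnc(Cc3ccccc3)c3ccccc23)CC1)Nc1cc(C(F)(F)F)ccc1Cl`, is the next step: 2-chloro-5-(trifluoromethyl)phenyl in place of 3-bromophenyl on an amide-type nitrogen. Within the data shown here, no measured step covers this exact change. The two steps that bear on it, a 4.9-fold lower number from compound 1 to compound 3 (0.69 log units; beyond the scatter) and a 1.4-fold higher number from compound 2 to compound 3 (0.15 log units; within the scatter), suggest that halogen-bearing phenyl groups on this nitrogen land near one another, so a step within the scatter, in either direction, is expected here, with a 1.0-fold higher number from compound 3 to compound 4 (0.01 log units; within the scatter) as the central guess. Compound 4 is therefore estimated at 4000 nM, with a range from 1500 nM to 11000 nM.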

Compound 4, half-maximal inhibitory concentration: 19500 nM
For compound 4 the middle estimate is 4.9-fold (0.69 log units) below the measured one; measured number outside the range, above it.
By their numbers in this assay, from the lowest: compounds 2 and 3 (each within the scatter of the next); then compounds 1 and 4 (each within the scatter of the next).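

The 2-chloro-5-(trifluoromethyl)phenyl group shows that a halogen-bearing phenyl on this amide-type nitrogen does not by itself keep the number low, since in this assay there is a 5.0-fold higher number from compound 3 to compound 4 (0.70 log units; beyond the scatter) and likewise a 7.1-fold higher number from compound 2 to compound 4 (0.85 log units; beyond the scatter) on this change. Among these compounds, its result instead matches the one non-halogen-only group so far, with a 1.0-fold higher number from compound 1 to compound 4 (0.01 log units; within the scatter), so the two groups whose names carry substituents numbered 2 and 5, 5-fluoro-2-methylphenyl and 2-chloro-5-(trifluoromethyl)phenyl, share the higher numbers, while 3,4-difluorophenyl and 3-bromophenyl share the lower numbers, and no compound here goes against that split. With only four compounds this is a description and not an explanation, and no measurement shown accounts for the change.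

The compounds shown leave open whether the chlorine, the trifluoromethyl group or the larger group as a whole (11 heavy atoms against 7) carries the step, which a 2-chlorophenyl or a 3-(trifluoromethyl)phenyl group on the same nitrogen would help to separate. Also open, from the compounds shown here alone, is how a phenyl group bearing an amine or a carboxylic acid would read in this assay.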